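The compounds below may be only part of what the source reports. "The series", "measured", "known", "first", "only" and "open" are said of these compounds alone.

Measured compounds in a functional assay on cardiac atrium for antagonist activity at histamine H2 receptor (Cavia porcellus); a lower number here means a less potent compound, a higher number a more potent compound, by a factor of ten per unit of this negative logarithm:
- compound 1, `N#CN/C(=N\CCNC(=O)c1ccccc1)NCCCCOc1cccc(CN2CCCCC2)c1`, gives 7.67
- compound 2, `N#CN/C(=N\CCCNC(=O)c1ccccc1)NCCCCOc1cccc(CN2CCCCC2)c1`, gives 6.6
- compound 3, `N#CN/C(=N\CCCCCNC(=O)c1ccccc1)NCCCOc1cccc(CN2CCCCC2)c1`, gives 6.58

Compound 1 and compound 2 differ in a single place: benzamidomethyl in place of benzamido on a saturated chain carbon, two bonds along the chain from a double-bonded nitrogen. This change costs potency, a number 1.07 log units lower from compound 1 to compound 2 (beyond the scatter). Compound 3 carries a different core; how that core differs from the core of compound 1 is not broken down here, and the two values alone show that compound 3 sits well under compound 1 in this assay. Compound 3 and compound 2, on the other hand, give numbers that lie within the scatter of each other, so no order between them is claimed.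

Compound 4, `N#CN/C(=N\CCCCCCNC(=O)c1ccccc1)NCCCOc1cccc(CN2CCCCC2)c1`, is not yet measured. It stands to compound 3 as compound 2 stands to compound 1: benzamidomethyl in place of benzamido on a saturated chain carbon, five bonds along the chain from a double-bonded nitrogen. This is the same kind of change, not the same change: in the pair compound 1 to compound 2 the place is two bonds along the chain from a double-bonded nitrogen, whereas here it is five bonds along the chain from a double-bonded nitrogen. For the measured compounds named here, only one instance of the change is measured.

For compound 4 the step is expected to go downward again but more weakly than the measured one, a number 0.38 log units lower from compound 3 to compound 4 (beyond the scatter), because compound 3 already starts from 6.58 and the place of the change is further out along the chain. Compound 4 is estimated at 6.2, with a range from 5.5 to 6.9.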

Compound 4, negative logarithm of the antagonist equilibrium constant: 6.6
Compound 4: middle estimate off by 0.40 log units, on the low side; the measured number falls inside the stated range.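

In this assay, the change from benzamido to benzamidomethyl, placed five bonds along the chain from a double-bonded nitrogen, gives a number 0.02 log units higher from compound 3 to compound 4 (within the scatter), so no shift in potency can be read from this instance. Set beside the only other instance, placed two bonds along the chain from a double-bonded nitrogen, the step does not carry over from one core to the other at a fixed size: the same change on two cores in this assay, a number 1.07 log units lower (beyond the scatter) from compound 1 to compound 2 and a number 0.02 log units higher (within the scatter) from compound 3 to compound 4, 1.09 log units apart, beyond the scatter of two such steps These two pairs show that a loss measured on one core cannot simply be transferred to another in this series, but they do not show which difference between the cores separates the two steps, since the place of the change and the rest of the core are not varied independently, nor do they give a rule for any further core.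

The compounds shown leave open whether the loss seen on the core of compound 1 recurs with a longer chain, such as 3-benzamidopropyl, on that same core, and whether a further lengthening to 3-benzamidopropyl on the core of compound 3 would remain as flat as the present step. They also leave open what happens when a free amine or a carboxylic acid takes the place of the benzamido group at the chain end on either core.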